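The compounds below may be only part of what the source reports. "The series", "measured", "known", "first", "only" and "open" are said of these compounds alone.

Compound 3 `Cc1cccc(NC(=O)Nc2c(-c3ccccc3)c3cc(C)c(C)cc3c(=O)n2C)c1` gives 840 nM in an assay on IM-9 cells for binding affinity to Substance-P receptor (Homo sapiens) (on this read-out higher numbers stand for weaker inhibition and lower numbers for stronger inhibition), the highest of the three numbers measured, with compound 1 `COc1ccccc1CN(C)C(=O)Nc1c(-c2ccccc2)c2cc(C)c(C)cc2c(=O)n1C` at 23 nM and compound 2 `Cc1cc2c(-c3ccccc3)c(NC(=O)N(C)Cc3ccccc3Cl)n(C)c(=O)c2cc1C` at 4.2 nM. Compound 4 `Cc1cc2c(-c3ccccc3)c(NC(=O)N(C)Cc3ccccc3)n(C)c(=O)c2cc1C` differs from compound 3 in one place: benzyl(methyl)amino in place of (3-methylphenyl)amino on a carbonyl carbon. Going by the values given here, the steps that bear on this change are a 37-fold higher number from compound 1 to compound 3 (1.56 log units; beyond the scatter) and a 200-fold higher number from compound 2 to compound 3 (2.30 log units; beyond the scatter), both large and both in the same direction, replacing a substituted benzyl(methyl)amino group with the aryl-amino group; the change from compound 3 to compound 4 runs the opposite way. Compound 4 is therefore expected to show a large step to lower numbers, a 56-fold lower number from compound 3 to compound 4 (1.75 log units; beyond the scatter), landing near its close relatives compound 1 and compound 2. The estimate for compound 4 in this assay is 15 nM, within 4 nM to 60 nM.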

Compound 4, half-maximal inhibitory concentration: 16 nM
Compound 4: middle estimate off by 1.1-fold (0.03 log units), on the low side; low and high end bracket the measured number.
By their numbers in this assay, from the lowest: compound 2; then compounds 4 and 1 (each within the scatter of the next); then compound 3.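

Changing the group on the carbonyl carbon matters even without a ring substituent: benzyl(methyl)amino alone gives a 53-fold lower number from compound 3 to compound 4 (1.72 log units; beyond the scatter). On that benzyl ring the two substituents differ, with a 1.4-fold lower number from compound 1 to compound 4 (0.16 log units; within the scatter) for losing methoxy but a 3.8-fold higher number from compound 2 to compound 4 (0.58 log units; beyond the scatter) for losing chloro, so only the chloro shifts the number beyond the scatter. Nothing measured here explains these steps.

On these data alone, this single swap adds both the methyl on nitrogen and the extra benzyl carbon, so their separate shares remain open. As far as these compounds go, whether fluoro or bromo would match chloro also remains open.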